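The source may report more compounds than this note shows. Statements on the series, on what has been measured and on what is new or still open speak of the compounds shown alone.

Measured in a functional assay on PC-3 cells (Homo sapiens) for antiproliferative activity, read by MTT assay, with a stated time of 48 h; on this read-out lower numbers stand for stronger inhibition and higher numbers for weaker inhibition:
- Compound 1 `COc1cc(N(Cc2ccc(C)cc2)C(=O)CSc2nc3ccccc3s2)cc(OC)c1OC`: > 80000 nM, a limit
- Compound 2 `COc1ccc(CN(C(=O)CSc2nc3ccccc3s2)c2cc(OC)c(OC)c(OC)c2)cc1O`: 2110 nM
- Compound 3 `COc1cc(CN(C(=O)CSc2nc3ccccc3s2)c2cc(OC)c(OC)c(OC)c2)cc(OC)c1OC`: > 80000 nM, a limit

Compound 2 is the only one of these with a number, and the other two stand at the limit of > 80000 nM in this assay, at which 2 of the 3 values shown sit. Compound 4 `COc1ccc2nc(SCC(=O)N(Cc3ccc(OC)c(O)c3)c3cc(OC)c(OC)c(OC)c3)sc2c1` differs from compound 2 by one change: methoxy in place of hydrogen on an aromatic carbon. In words, this is methoxy in place of hydrogen on an aromatic carbon. The measured steps, an at least 37-fold lower number from compound 1 to compound 2 (1.57 log units; beyond the scatter) and an at least 37-fold higher number from compound 2 to compound 3 (1.57 log units; beyond the scatter), are large, but both lie on a saturated chain carbon bound to an amide-type nitrogen, not at this site. They show that a single change can matter greatly in this assay, but they favour no direction here, so the range is kept wide. The expected step is a 1.0-fold lower number from compound 2 to compound 4 (0.00 log units; within the scatter), with none expected beyond the scatter. For compound 4 the estimated value is 2100 nM, with an expected range of 400 nM to 11000 nM.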

Compound 4, half-maximal inhibitory concentration: 4110 nM
Compound 4: the middle estimate sits 2.0-fold (0.29 log units) below what was measured; measured number inside the range.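

In this assay, among the compounds shown here, going from 1,3-benzothiazol-2-yl to 6-methoxy-1,3-benzothiazol-2-yl gives a 1.9-fold higher number from compound 2 to compound 4 (0.29 log units; within the scatter) and so cannot be told apart from no step at all. The earlier steps shown here all lay on the saturated chain carbon bound to the amide-type nitrogen, where single changes were large. For the compounds shown here, this result is the first reading at an aromatic carbon of the fused system, and there methoxy is accepted with no loss beyond the scatter.

Going by these compounds, whether an amine, a carboxylic acid or a longer alkoxy chain at this carbon would behave like methoxy stays open. Nothing shown gives a cause for this step.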